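A few compounds are considered here, and "the series" means these few. Any claim that something is new, unique, unknown or untested is made for them only; others in the source may bear on it.

Compounds measured in an assay on isolated protein for inhibition of Dihydrofolate reductase (Mus musculus); a higher number here means a more potent compound, by a factor of ten per unit of this negative logarithm, a lower number a less potent compound:

Compound 1, `CC1(C)N=C(N)N=C(N)N1c1ccc(CCCCc2ccccc2)c(Cl)c1` — 7.92
Compound 2, `CN(C)C(=O)c1cccc(NC(=O)NCc2cccc(N3C(N)=NC(N)=NC3(C)C)c2)c1` — 7.77
Compound 3, `CC1(C)N=C(N)N=C(N)N1c1ccc(CCCCc2cccc(Cl)c2S(=O)(=O)F)c(Cl)c1` — 8.2

Compound 3 stands highest of the three numbers. Its nearest neighbour is compound 1, whose value in this assay sits somewhat lower but within the scatter of repeated measurements, so the two cannot be told apart with confidence. Compound 2 lies further off, and that gap is beyond the scatter, so compound 3 can be said to outperform compound 2 but not compound 1.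

Compound 4, `CC1(C)N=C(N)N=C(N)N1c1ccc(CCCCc2ccccc2S(=O)(=O)F)c(Cl)c1`, has not yet been measured in this assay. It differs from compound 3 in one place: hydrogen in place of chloro on an aromatic carbon. The chloro is removed and the fluorosulfonyl group is kept.

Among the measured compounds shown here, no step between measured compounds isolates this change, so the expectation rests on the neighbourhood of compound 1 and compound 3, both of which sit close together. Compound 4 is expected to give a step of a number 0.20 log units lower from compound 3 to compound 4 (within the scatter), likely within the scatter. The estimate for compound 4 in this assay is 8, with a range from 7.6 to 8.4.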

Compound 4, logarithm of the reciprocal of the active concentration, log(1/C): 7.77
Compound 4: middle estimate off by 0.23 log units, on the high side; the measured number falls inside the stated range.
By their numbers in this assay, from the lowest: compounds 2, 4, 1 and 3 (each within the scatter of the next, the first and the last beyond it).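

Within this assay, hydrogen in place of chloro on this aromatic carbon, ortho to a fluorosulfonyl group, gives a number 0.43 log units lower from compound 3 to compound 4 (beyond the scatter) as a modest change, showing that this position can register a substitution when the fluorosulfonyl group is present. Fluorosulfonyl in place of hydrogen gives a number 0.15 log units lower from compound 1 to compound 4 (within the scatter) and so cannot be told apart from no change, which means that the fluorosulfonyl group without the chloro brings no readable difference. Nothing measured here gives a reason for either step.

The compounds shown leave open whether a fluoro, a methyl or a methoxy group on this carbon would match the chloro or the hydrogen. They also leave open whether a chloro on this carbon without the fluorosulfonyl group would produce any step at all.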